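A few compounds are considered here, and "the series" means these few. Any claim that something is new, unique, unknown or untested is made for them only; others in the source may bear on it.

Measured compounds:
compound 2 `Cc1cccc(NC(=O)Nc2cc(Oc3ccc4nc(NC(=O)C5CC5)sc4c3)ccc2F)c1` — 93 nM
compound 1 `O=C(Nc1nc2ccc(Oc3ccc(F)c(NC(=O)C4(c5cccc(C(F)(F)F)c5)CC4)c3)cc2s1)C1CC1` — "not determined" (no result reported)

Among the measured compounds shown here, compound 2 is the one compound with a number here. In an assay for binding affinity to receptor-interacting serine/threonine-protein kinase 3 (Homo sapiens), read by KINOMEscan and polymerase chain reaction, with a stated time of 1 h (on this read-out higher numbers stand for weaker binding and lower numbers for tighter binding), compound 2 gives 93 nM, the only number shown; compound 1 was entered as "not determined" (no result reported), so there is no second value to set beside it and nothing on which compound 2 could be ranked.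

Compound 3 `O=C(Nc1cccc(Br)c1)Nc1cc(Oc2ccc3nc(NC(=O)C4CC4)sc3c2)ccc1F` is the next step from compound 2. The two structures differ in one place: bromo in place of methyl on an aromatic carbon. Everything else, including the shared core and the amide on its far end, stays as in compound 2.

For the measured compounds named here, no pair of measured compounds differing in one place is available, so the size of this step has to be judged from the change alone. A single-atom swap of this kind, with no ring, no donor or acceptor and no charge involved, is expected to move the dissociation constant in this assay by no more than the scatter, if anything toward slightly tighter binding; the expected step is a 1.2-fold lower number from compound 2 to compound 3 (0.09 log units; within the scatter).

Compound 3 is therefore estimated at 75 nM, with a range of 30 nM to 220 nM.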

Compound 3, dissociation constant: 81 nM
Estimate against measurement, compound 3: 1.1-fold (0.03 log units) below; the measured number falls inside the stated range.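

Among the compounds shown here, compound 3 supplies the first step that can be read here: with the 3-methylphenyl of compound 2 exchanged for 3-bromophenyl, this assay shows a 1.1-fold lower number from compound 2 to compound 3 (0.06 log units; within the scatter) and so does not tell the two compounds apart. At this place, on an aromatic carbon meta to a large group, a methyl and a bromo are therefore interchangeable as far as this read-out goes, something a single number for compound 2 could not show. Nothing given here bears on why the two groups read alike.

What the compounds shown leave open is how much this position tolerates at all, since methyl and bromo are the only two groups compared on it, and a chloro, a methoxy, a trifluoromethyl, an amine or a carboxylic acid in the same place might read quite differently. From the compounds shown here alone, whether the same indifference holds elsewhere on this ring, or for a longer chain in place of the methyl or bromo, also remains unknown, and compound 1 offers no help, with no number to read.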